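Three Amide Caps on One Core, a Fourth Awaited

A few compounds are considered here, and "the series" means these few. Any claim that something is new, unique, unknown or untested is made for them only; others in the source may bear on it.

Measured so far in an assay on HEK293 cells for inhibition of Neuropeptide Y receptor type 5 (Homo sapiens); on this read-out lower numbers stand for stronger inhibition and higher numbers for weaker inhibition:
compound 1 `COc1ccc(CNC(=O)C2CCN(C(=O)Cn3c(=O)sc4ccc(Cl)cc43)CC2)cc1` gives 2.3 nM
compound 2 `O=C(Nc1nc2cc(Cl)ccc2o1)C1CCN(C(=O)Cn2c(=O)sc3ccc(Cl)cc32)CC1` gives 3.8 nM
compound 3 `COc1ccc(NC(=O)C2CCN(C(=O)Cn3c(=O)sc4ccc(Cl)cc43)CC2)cn1` gives 2.3 nM

Compound 3 stands level with compound 1 at the digits shown, the two of them together at the low end of the three numbers; its nearest neighbour is compound 1 and its furthest compound 2, yet even that gap, a 1.7-fold lower number from compound 2 to compound 3 (0.22 log units; within the scatter), stays within the scatter.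

Compound 4 `CC(=O)c1cccc(NC(=O)C2CCN(C(=O)Cn3c(=O)sc4ccc(Cl)cc43)CC2)c1` differs from compound 3 in one place: 3-acetylphenyl in place of 6-methoxypyridin-3-yl on an amide-type nitrogen. Going by the values given here, the steps that bear on this are the three exchanges at the same amide-type nitrogen: a 1.7-fold higher number from compound 1 to compound 2 (0.22 log units; within the scatter), no change at the digits printed from compound 1 to compound 3 (within the scatter) and a 1.7-fold lower number from compound 2 to compound 3 (0.22 log units; within the scatter). None of them moved the number beyond the scatter, although the groups swapped in and out varied widely. On that basis compound 4 is expected to show a 1.5-fold higher number from compound 3 to compound 4 (0.18 log units; within the scatter) in this assay, a step not clearly beyond the scatter in either direction. The estimate for compound 4 is therefore 3.5 nM, with a range from 1.2 nM to 10 nM.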

Compound 4, half-maximal inhibitory concentration: 0.59 nM
Beside the measured number, compound 4's estimate is 5.9-fold (0.77 log units) above it; measured number below the stated range.
By their numbers in this assay, from the lowest: compound 4; then compounds 1, 3 and 2 (each within the scatter of the next).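

Until now this amide-type nitrogen had looked indifferent to the group it carried, but it is not: in this assay the change to 3-acetylphenyl gives a 3.9-fold lower number from compound 3 to compound 4 (0.59 log units; beyond the scatter) and so goes beyond the scatter, as none of the earlier exchanges did. The same group also gives a 3.9-fold lower number from compound 1 to compound 4 (0.59 log units; beyond the scatter) and a 6.4-fold lower number from compound 2 to compound 4 (0.81 log units; beyond the scatter) in the same direction, which places compound 4 as the most potent of the four, though each step is modest. Nothing shown here accounts for this step.

The change swaps the ring and its substituent at once, so the compounds shown do not separate the part played by the carbon-only ring from that of the acetyl group. As far as these compounds go, how a plain phenyl would read stays open, as does the effect of a carboxylic acid or an amine in place of the acetyl.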